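A few compounds are considered here, and "the series" means these few. Any claim that something is new, unique, unknown or untested is made for them only; others in the source may bear on it.

Working notes on the octylsulfonamide benzoic acid series. The measured members are compound 1 `CCCCCCCCS(=O)(=O)Nc1cc(-c2ccc(CCCC)cc2)ccc1C(=O)O`, compound 2 `CCCCCCCCS(=O)(=O)Nc1cc(-c2ccccc2-c2ccccc2)ccc1C(=O)O` and compound 3 `CCCCCCCCS(=O)(=O)Nc1ccc(-c2ccc(CCCC)cc2)cc1C(=O)O`, all read in an assay on mitochondria (strain BALB/c) for inhibition of glycerol-3-phosphate acyltransferase 1, mitochondrial (Mus musculus), read by scintillation counting, with a stated time of 10 min; a higher number here means a weaker inhibitor, a lower number a stronger inhibitor. In this assay compound 1 gives 15700 nM, compound 2 gives 17100 nM and compound 3 gives 9000 nM. Compound 3 sits at the low end of the three numbers, but the gap to compound 1 and the gap to compound 2 both fall within the usual scatter of repeated measurements, so no ranking among the three is supported by these data. Going by the values given here, no pair of the measured compounds differs in one place only, so no single-change step is available as a guide.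

The next member is compound 4 `CCCCCCCCS(=O)(=O)Nc1ccc(C(=O)c2ccccc2OC)cc1C(=O)O`. It differs from compound 3 by (2-methoxyphenyl)carbonyl in place of 4-butylphenyl on an aromatic carbon. Among the compounds with values here, nothing among the measured compounds shows how such a replacement moves this assay, and all three measured numbers cluster closely. The expectation for the step from compound 3 to compound 4 in this assay is therefore a 1.3-fold higher number from compound 3 to compound 4 (0.12 log units; within the scatter), a change not beyond the scatter. For compound 4 the estimate in this assay is 12000 nM, with a range from 4000 nM to 40000 nM.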

Compound 4, half-maximal inhibitory concentration: 59200 nM
Compound 4: middle estimate off by 4.9-fold (0.69 log units), on the low side, and the stated range ends below it.
By their numbers in this assay, from the lowest: compounds 3, 1 and 2 (each within the scatter of the next); then compound 4.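

Going by these compounds alone, the change of 4-butylphenyl to (2-methoxyphenyl)carbonyl, on an aromatic carbon meta to a carboxy group and para to a large group, gives the first step that lies beyond the scatter: in this assay the swap produces a 6.6-fold higher number from compound 3 to compound 4 (0.82 log units; beyond the scatter), so compound 4 is a weaker inhibitor than compound 3, and this position does not tolerate every group of similar size. The two groups match in heavy-atom count and each holds one six-membered aromatic ring of carbon only, so the step comes with a swap that keeps the ring but adds a carbonyl, a methoxy group and hydrogen-bond acceptors absent from 4-butylphenyl. No measurement on these compounds accounts for the step.

Going by these compounds, the step changes several features at once, so it remains open whether the loss follows the carbonyl, the 2-methoxy group or the absence of the butyl chain; a plain phenylcarbonyl or a (4-butylphenyl)carbonyl group at this position would separate these. Also open, on these data alone, is whether the same change would move the number similarly with a hexyl chain in place of the octyl chain.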